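Swapping fluoro for iodo: an expected half-life

The compounds below may be only part of what the source reports. "The series", "measured", "known", "first", "only" and "open" are said of these compounds alone.

Compound 1 `CC#C[C@@H](Cc1nnn[nH]1)c1ccc(OCc2ccc3sc(F)c(-c4ccccc4C)c3c2)cc1` gives 0.367 h
Compound 2 `CC#C[C@@H](Cc1nnn[nH]1)c1ccc(OCc2ccc3scc(-c4ccc(OCCOC)cc4C)c3c2)cc1` gives 0.217 h
Compound 3 `CC#C[C@@H](Cc1nnn[nH]1)c1ccc(OCc2ccc3sc(F)c(-c4ccc(OCCOC)cc4C)c3c2)cc1` gives 0.35 h

All three values come from an ADME assay on microsomes from liver (Rattus norvegicus) for metabolic stability (on this read-out lower numbers stand for a shorter-lived compound and higher numbers for a longer-lived compound), and lie within the usual scatter of one another, so compound 1 stands level with compound 2 and compound 3 on these numbers. The next compound, compound 4 `CC#C[C@@H](Cc1nnn[nH]1)c1ccc(OCc2ccc3sc(I)c(-c4ccccc4C)c3c2)cc1`, keeps the core of compound 1 and changes one group (iodo in place of fluoro on an aromatic carbon). Here fluoro gives way to iodo on the five-membered aromatic ring with 1 sulfur, next to the ring sulfur.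

The closest evidence is the change at that same carbon, where fluoro replaces hydrogen, giving a 1.6-fold higher number from compound 2 to compound 3 (0.21 log units; within the scatter). The other measured change puts 2-methoxyethoxy in place of hydrogen on an aromatic carbon, giving a 1.0-fold lower number from compound 1 to compound 3 (0.02 log units; within the scatter), and it says less about this swap. Neither step leaves the scatter. Within the data shown here, no compound carrying iodo has been measured, so the evidence is indirect. No step beyond the scatter is expected in this assay, and no direction can be called with confidence. The estimated change is a 1.1-fold lower number from compound 1 to compound 4 (0.06 log units; within the scatter) and it stays small. For compound 4 the expected half-life is 0.32 h, with an estimated range of 0.15 h to 0.62 h.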

Compound 4, half-life: 0.483 h
Compound 4: middle estimate off by 1.5-fold (0.18 log units), on the low side; low and high end bracket the measured number.
By their numbers in this assay, from the lowest: compounds 2, 3, 1 and 4 (each within the scatter of the next, the first and the last beyond it).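

In this assay, the swap at the aromatic carbon next to the ring sulfur gives a 1.3-fold higher number from compound 1 to compound 4 (0.12 log units; within the scatter) and so does not separate iodo from fluoro at this position. Before this result, the only reading at this carbon was the change from hydrogen to fluoro, which gave a 1.6-fold higher number from compound 2 to compound 3 (0.21 log units; within the scatter) in a different setting, with a 2-methoxyethoxy group on the 2-methylphenyl ring; now a second halogen has been read there too, on the simpler core of compound 1, and again the step stays within the usual scatter, so across these compounds no group at this carbon has yet been seen to shift the half-life beyond that scatter. Nothing available gives a measured reason for this result, so the small step remains a plain observation.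

Going by these compounds, what a methyl, a nitrile or an amine on this same carbon would do to the half-life remains open. So does whether iodo would read the same way alongside the 2-methoxyethoxy group of compound 3, and whether hydrogen at this carbon on the core of compound 1 would sit level with fluoro and iodo.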